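Fluoro to trifluoromethyl: notes on a small series

A few compounds are considered here, and "the series" means these few. Any claim that something is new, unique, unknown or untested is made for them only; others in the source may bear on it.

Measured so far in a functional assay on HepG2 cells (Homo sapiens) for cytotoxicity, read by MTT assay, with a stated time of 24 h; a lower number here means a stronger inhibitor, a higher number a weaker inhibitor:
- compound 1 `Cc1ccc(S(=O)(=O)N2C/C(=C\c3cccnc3)C(=O)/C(=C/c3ccccc3F)C2)cc1` gives 4200 nM in this read-out
- compound 2 `O=C1/C(=C/c2cccnc2)CN(S(=O)(=O)c2ccc(Cl)cc2)C/C1=C\c1ccccc1F` gives 12400 nM in this read-out
- compound 3 `O=C1/C(=C/c2cccnc2)CN(S(=O)(=O)c2ccc(Br)cc2)C/C1=C\c1ccccc1F` gives 8700 nM in this read-out

Compound 2 sits at the high end of these numbers, an end it shares with its nearest neighbour. The gap there is a 1.4-fold lower number from compound 2 to compound 3 (0.15 log units; within the scatter) and the gap to the lowest number is a 3.0-fold higher number from compound 1 to compound 2 (0.47 log units; beyond the scatter) in the other direction.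

The change to compound 4 `O=C1/C(=C/c2cccnc2)CN(S(=O)(=O)c2ccc(Cl)cc2)C/C1=C\c1ccccc1C(F)(F)F` is trifluoromethyl in place of fluoro on an aromatic carbon and reads, in words, trifluoromethyl in place of fluoro on an aromatic carbon, ortho to a large group. Within the data shown here, no measured step touches this place. All of them swap methyl, chloro and bromo elsewhere on the shared core, so they serve only as a gauge of how far one swap has moved the numbers here. Another modest example is a 2.1-fold higher number from compound 1 to compound 3 (0.32 log units; beyond the scatter) in the same set. They give no direction for the new change. With compound 2 at 12400 nM near the top of a narrow span, a step beyond the scatter is not expected. The estimated step is a 1.4-fold lower number from compound 2 to compound 4 (0.14 log units; within the scatter) with no firm direction behind it. In this assay the estimate for compound 4 is 9000 nM with an expected range from 3500 nM to 22000 nM on this thin basis.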

Compound 4, half-maximal inhibitory concentration: 3620 nM
Beside the measured number, compound 4's estimate is 2.5-fold (0.40 log units) above it; low and high end bracket the measured number.
By their numbers in this assay, from the lowest: compounds 4 and 1 (each within the scatter of the next); then compounds 3 and 2 (each within the scatter of the next).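

In this assay, the only change shown at this place, trifluoromethyl in place of fluoro, gives a 3.4-fold lower number from compound 2 to compound 4 (0.53 log units; beyond the scatter). The earlier steps shown here, all swaps of methyl, chloro and bromo elsewhere on the shared core, could say nothing about this place; it now proves able to move the number beyond the scatter, and the move is towards a stronger inhibitor, though still a modest one. Nothing shown here accounts for why the 2-(trifluoromethyl)phenyl compound reads lower than the 2-fluorophenyl compound, and no supporting data on the cause are available.

Going by these compounds, the step rests on a single pair with chloro held fixed at the other site, so it remains open whether the same change lowers the number when methyl or bromo stands there instead. Also open, on these data alone, is how far this place tolerates groups of another kind, such as a methoxy, a nitrile, an amine or a carboxylic acid, and whether any of them would carry the number further in the same direction.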